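The source may report more compounds than this note shows. Statements on the series, on what has been measured and on what is new or still open speak of the compounds shown alone.

Working notes on the series. Of the compounds shown here, two on a shared core have been measured in a functional assay on MGC-803 cells (Homo sapiens) for inhibition, read by sulforhodamine B assay; on this read-out lower numbers stand for stronger inhibition and higher numbers for weaker inhibition. Compound 1 `Cc1ccc(NC2=CC(=O)c3nc4n(c3C2=O)[C@H]2OC[C@@H](O)[C@H]2OC4)cc1` gives 1420 nM, and compound 2 `COc1cccc(NC2=CC(=O)c3c(nc4n3[C@H]3OC[C@@H](O)[C@H]3OC4)C2=O)c1` gives 1790 nM. Compound 1 stands at the low end of the two numbers, with compound 2 within the scatter of it, so the pair cannot be told apart. Compound 3 `O=C1C=C(Nc2ccc(C(F)(F)F)cc2)C(=O)c2c1nc1n2[C@H]2OC[C@@H](O)[C@H]2OC1` awaits measurement; it differs from compound 1 in one place: trifluoromethyl in place of methyl on an aromatic carbon. Going by the values given here, no step between measured compounds exists to gauge this change. The step of a 1.1-fold higher number from compound 1 to compound 3 (0.02 log units; within the scatter) is expected to stay within the scatter, in no clear direction. Compound 3 is expected to give 1500 nM, with a range from 600 nM to 4000 nM.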

Compound 3, half-maximal inhibitory concentration: 2820 nM
For compound 3 the middle estimate is 1.9-fold (0.27 log units) below the measured one; the measured number falls inside the stated range.
By their numbers in this assay, from the lowest: compounds 1, 2 and 3 (each within the scatter of the next).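

In this assay the first change gauged at this position, trifluoromethyl in place of methyl on an aromatic carbon para to a large group, gives a 2.0-fold higher number from compound 1 to compound 3 (0.30 log units; within the scatter) and so does not separate the two compounds. The position therefore accepts the larger 4-(trifluoromethyl)phenyl in place of 4-methylphenyl without a step beyond the scatter. No evidence on the cause accompanies this step.

From the compounds shown here alone, whether an amine or a carboxylic acid at this same ring carbon would give a step beyond the scatter stays open. Going by these compounds, a longer chain such as n-butyl at this carbon is equally open.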